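Chloro for methyl on the shared core: cytotoxicity

The compounds below may be only part of what the source reports. "The series", "measured", "known", "first", "only" and "open" are said of these compounds alone.

Compound 1 `Cc1ccc2nc(Nn3c(-c4ccc([N+](=O)[O-])cc4)nnc3-c3cccnc3)sc2c1`: 64.4 ug/mL
Compound 2 `O=[N+]([O-])c1ccc(-c2nnc(-c3cccnc3)n2Nc2nc3ccc(Cl)cc3s2)cc1`: 53.7 ug/mL
Compound 3 `Cc1cccc2sc(Nn3c(-c4ccc(Cl)cc4)nnc3-c3cccnc3)nc12`: 36.5 ug/mL

In an ADME assay on MT4 cells (Homo sapiens) for cytotoxicity, read by MTT assay, with a stated time of 5 days (on this read-out higher numbers stand for lower toxicity in this test and lower numbers for higher toxicity in this test), compound 1 gives 64.4 ug/mL. Compound 2 is compound 1 with chloro in place of methyl on an aromatic carbon, and in this assay compound 2 gives 53.7 ug/mL; the step is a 1.2-fold lower number from compound 1 to compound 2 (0.08 log units; within the scatter). Compound 3, in this assay, gives 36.5 ug/mL. The difference between the core of compound 3 and the core of compound 1 is not broken down here; the two differ in more than one place.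

Compound 4 `Clc1ccc(-c2nnc(-c3cccnc3)n2Nc2nc3c(Cl)cccc3s2)cc1` is not yet measured. It is compound 3 with chloro in place of methyl on an aromatic carbon. This is the same kind of change as that from compound 1 to compound 2, but at a different place: in compound 4 the chloro stands ortho to a fused ring and meta to a fused ring, whereas in compound 2 it stands meta to a fused ring and para to a fused ring.

Because the step of a 1.2-fold lower number from compound 1 to compound 2 (0.08 log units; within the scatter) stayed within the scatter, the step for compound 4 is expected to be small as well, about a 1.2-fold lower number from compound 3 to compound 4 (0.07 log units; within the scatter). Compound 4 is therefore estimated at 31 ug/mL in this assay, with a likely range from 15 ug/mL to 62 ug/mL.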

Compound 4, half-maximal cytotoxic concentration: 27.2 ug/mL
Estimate against measurement, compound 4: 1.1-fold (0.06 log units) above, within the range that was stated.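

In this assay, chloro in place of methyl on the second core gave a 1.3-fold lower number from compound 3 to compound 4 (0.13 log units; within the scatter) and thus agreed with the earlier step on the first core: (the same change on two cores in this assay, a 1.2-fold lower number (0.08 log units; within the scatter) from compound 1 to compound 2 and a 1.3-fold lower number (0.13 log units; within the scatter) from compound 3 to compound 4, 1.1-fold (0.05 log units) apart, within the scatter of two such steps). Across these two cores, then, the change carried over as a small step, even though the chloro sits at a different place on the ring in each pair. This does not show that the change has a consistent direction, as both steps lie within the scatter, and two pairs say nothing about how it would behave on other cores or in other tests.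

The compounds shown leave open how an amine, a methoxy group or a longer chain would read in place of the methyl or chloro on these aromatic carbons. They also leave open whether the step would stay as small on a core carrying a carboxylic acid on one of its outer rings.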